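The source may hold more compounds than are shown below. What is called first, only, known or untested is meant among the compounds shown, and "the series" means these compounds.

Series notes. In a functional assay on MDA-MB-231 cells (Homo sapiens) for cytotoxicity, read by MTT assay, with a stated time of 72 h (on this read-out higher numbers stand for weaker inhibition and lower numbers for stronger inhibition), compound 1 `N=C(Nc1cccc(C(F)(F)F)c1)c1cc2c(-c3ccccc3)n[nH]c2cn1` gives 22300 nM. Compound 2 `N=C(Nc1ccccc1)c1cc2c(-c3ccccc3)n[nH]c2c(NC2CCCCC2)n1` gives 1710 nM in this assay. Compound 3 `COc1cc(Nc2nc(C(=N)Nc3cccc(C(F)(F)F)c3)cc3c(-c4ccccc4)n[nH]c23)cc(OC)c1OC` gives 7600 nM in this assay, which is the second highest of the three numbers: compound 1 sits above it beyond the scatter, and compound 2 below it beyond the scatter. Among the measured compounds shown here, compound 2 and compound 3 differ in two places at once, so no single step between them is separable from these data.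

Compound 4 `N=C(Nc1cccc(C(F)(F)F)c1)c1cc2c(-c3ccccc3)n[nH]c2c(NC2CCCCC2)n1` is not yet measured in this assay. Relative to compound 3 the change is cyclohexyl in place of 3,4,5-trimethoxyphenyl on a nitrogen on an aromatic ring. For the measured compounds named here, the only cyclohexyl-bearing compound with a number, compound 2, holds the lowest value of the three with 1710 nM, so the step is expected to run downward, with a size of a 3.0-fold lower number from compound 3 to compound 4 (0.48 log units; beyond the scatter) in this assay. For compound 4 the expected value in this assay is 2500 nM, with a range from 800 nM to 8000 nM.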

Compound 4, half-maximal inhibitory concentration: 24600 nM
Compound 4: the middle estimate sits 9.8-fold (0.99 log units) below what was measured, outside the stated range (above it).
By their numbers in this assay, from the lowest: compound 2; then compound 3; then compounds 1 and 4 (each within the scatter of the next).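

In this assay the cyclohexylamino group in place of hydrogen on an aromatic carbon leaves the number unmoved, with a 1.1-fold higher number from compound 1 to compound 4 (0.04 log units; within the scatter) on the core of compound 1, while cyclohexyl in place of 3,4,5-trimethoxyphenyl on the nitrogen gives a 3.2-fold higher number from compound 3 to compound 4 (0.51 log units; beyond the scatter) as a modest step upward. The large step is trifluoromethyl in place of hydrogen on an aromatic carbon, with a 14-fold higher number from compound 2 to compound 4 (1.16 log units; beyond the scatter) in this pair, so the low number of compound 2 goes with that hydrogen and not with cyclohexyl alone. Nothing at hand bears on the origin of these steps.

Still open, as far as these compounds go, is whether 3,4,5-trimethoxyphenyl on the nitrogen gives a similar rise with trifluoromethyl in place of hydrogen. Also open, from the compounds shown here alone, is how a morpholine or a short alkylamine would compare in place of the cyclohexylamino group.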